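The source may report more compounds than this note shows. Statements on the series, on what has been measured and on what is new or still open speak of the compounds shown alone.

In a functional assay on MCF7 cells (Homo sapiens) for antiproliferative activity, read by MTT assay, with stated times of 24 h and 72 h (a lower number here means a stronger inhibitor, a higher number a weaker inhibitor), compound 1 (`COc1ccc([C@@H]2[C@H](Oc3ccccc3)C(=O)N2c2cc(OC)c(OC)c(OC)c2)cc1`) gives 35000 nM and compound 2 (`COc1ccc([C@@H]2[C@@H](Oc3ccccc3)C(=O)N2c2cc(OC)c(OC)c(OC)c2)cc1`) gives 6900 nM. That gap is a 5.1-fold lower number from compound 1 to compound 2 (0.71 log units; beyond the scatter), and it goes with the fact that compounds 1 and 2 differ only in the configuration as drawn. Compound 3 (`COc1ccc([C@@H]2[C@H](Oc3ccccc3)C(=O)N2c2cc(OC)c(OC)c(OC)c2)cc1OC`) gives 26000 nM, which is level with compound 1 within the scatter and clearly higher than compound 2.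

Compound 4 (`COc1cc(N2C(=O)[C@@H](Oc3ccccc3)[C@H]2c2ccc(C#N)cc2)cc(OC)c1OC`) keeps the configuration drawn for compound 3 but exchanges one aryl group, with 4-cyanophenyl in place of 3,4-dimethoxyphenyl on a saturated ring carbon. The configuration step therefore does not carry over to this change. The step that bears on it is the added methoxy on the same aryl group, a 1.3-fold lower number from compound 1 to compound 3 (0.13 log units; within the scatter), which was small. Within the data shown here, no measured compound carries a nitrile, so this is only weak guidance, and no step beyond the scatter is expected in this assay. The expected change is a 1.3-fold higher number from compound 3 to compound 4 (0.13 log units; within the scatter), with the direction left uncertain. Compound 4 is estimated at 35000 nM, within an expected range of 10000 nM to 100000 nM.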

Compound 4, half-maximal inhibitory concentration: 31600 nM
Estimate against measurement, compound 4: 1.1-fold (0.04 log units) above; measured number inside the range.
By their numbers in this assay, from the lowest: compound 2; then compounds 3, 4 and 1 (each within the scatter of the next).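

In this assay, among these compounds, the earlier compounds had tested only an added methoxy on the aryl group at this saturated ring carbon, whereas compound 4 replaces 3,4-dimethoxyphenyl with 4-cyanophenyl, a nitrile-bearing group, and the step is a 1.2-fold higher number from compound 3 to compound 4 (0.08 log units; within the scatter). Cyano in place of methoxy on an aromatic carbon gives the same picture, with a 1.1-fold lower number from compound 1 to compound 4 (0.04 log units; within the scatter), so neither exchange separates these compounds beyond the scatter. Nothing measured here offers a reason for this result.

The compounds shown do not tell whether the configuration step, a 5.1-fold lower number from compound 1 to compound 2 (0.71 log units; beyond the scatter), also holds for compounds carrying 4-cyanophenyl. They also leave open whether an amine or a carboxylic acid on this aryl group would give a step beyond the scatter.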